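This account rests on a few compounds, and the source may have more. Where it says the series, first, only, none or still open, it means among the compounds named here.

Two compounds have been measured so far in an ADME assay on the whole organism for pharmacokinetics, with Rattus norvegicus as the target; a lower number here means that the compound disappears faster, a higher number that the compound lasts longer:

compound 1 `Cc1cc(C)c(NC(=O)c2sccc2S(=O)(=O)Nc2onc(C)c2Cl)c(Cl)c1` gives 2.6 h here
compound 2 `CCCS(=O)(=O)c1cc(C)cc(C)c1NC(=O)c1sccc1S(=O)(=O)Nc1onc(C)c1Cl` gives 1.3 h here

With only these two numbers to go on, compound 2 at 1.3 h lies within the usual scatter of compound 1 at 2.6 h, so the two cannot be told apart. The next compound, compound 3 `Cc1cc(C)c(NC(=O)c2sccc2S(=O)(=O)Nc2onc(C)c2Cl)c(-c2ncco2)c1`, has 1,3-oxazol-2-yl in place of propylsulfonyl on an aromatic carbon of the shared core. Among the measured compounds shown here, one measured step bears on this change, as it exchanged chloro for propylsulfonyl on that same carbon. That step came out as a 2.0-fold lower number from compound 1 to compound 2 (0.30 log units; within the scatter) and stays within the scatter. For the measured compounds named here, a single step is thin evidence, and no measured compound yet carries 1,3-oxazol-2-yl. Even so, the swap is expected to give no shift beyond the scatter in this assay for now. The expected step is a 1.4-fold higher number from compound 2 to compound 3 (0.14 log units; within the scatter) and it would stay inside the scatter. Compound 3 is estimated at 1.8 h, with an expected range from 0.9 h to 3.6 h in the coming measurement.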

Compound 3, half-life: 5.3 h
Compound 3: middle estimate off by 2.9-fold (0.47 log units), on the low side; measured number outside the range, above it.
By their numbers in this assay, from the lowest: compounds 2 and 1 (each within the scatter of the next); then compound 3.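

In this assay, the group on this aromatic carbon can move the number beyond the scatter, which the step from chloro to propylsulfonyl could not show: 1,3-oxazol-2-yl in place of propylsulfonyl gives a clear rise (a 4.1-fold higher number from compound 2 to compound 3 (0.61 log units; beyond the scatter)). Among the compounds shown here, the same ring also stands apart from chloro (a 2.0-fold higher number from compound 1 to compound 3 (0.31 log units; beyond the scatter)), so compound 3 lasts longest of the three, while the two earlier groups remain within the scatter of each other and the ring is the only one of the three groups that clears the scatter against both others. Nothing available here gives a cause for these steps.

For the compounds shown here, with only three groups at this place, and only one of them a ring, it stays open whether the higher number belongs to 1,3-oxazol-2-yl as such or would appear with any five-membered aromatic ring, such as a thiazole or an imidazole. Going by these compounds, how an amine, a carboxylic acid or a shorter sulfonyl group such as methylsulfonyl would compare on this same carbon also stays open.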